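The source may report more compounds than this note shows. Statements on the series, on what has been measured and on what is new or still open speak of the compounds shown alone.

In an ADME assay on the whole organism (Mus musculus, strain Swiss Webster) for pharmacokinetics, read by LC-MS, at a dose of 50 mg/kg by the oral route (a higher number here means more compound in the circulation at the dose given, a lower number less compound in the circulation), compound 3 (`O=C(Nc1ccc(F)c(-c2nc3ncc(C(F)(F)F)cc3[nH]2)c1)N1CCCC1`) gives 1080 nM and sits within the scatter of compound 1 (`O=C(Nc1ccc(F)c(-c2nc3ncc(-c4cccc(F)c4F)cc3[nH]2)c1)N1CCCC1`) at 1830 nM while standing far under compound 2 (`O=C(Nc1ccc(F)c(-c2nc3ncc(-c4cccnc4F)cc3[nH]2)c1)N1CCCC1`) at 25600 nM in this series. Compound 4 (`O=C(Nc1ccc(F)c(-c2nc3ncc(-c4ccc(O)cc4)cc3[nH]2)c1)N1CCCC1`) has 4-hydroxyphenyl in place of trifluoromethyl on an aromatic carbon. Two measured steps put trifluoromethyl in place of a ring at that carbon: a 1.7-fold lower number from compound 1 to compound 3 (0.23 log units; within the scatter) and, for the ring holding nitrogen, a 24-fold lower number from compound 2 to compound 3 (1.37 log units; beyond the scatter) as well. The new ring of compound 4 holds no nitrogen, so the guide is the step of a 1.7-fold lower number from compound 1 to compound 3 (0.23 log units; within the scatter) and no step beyond the scatter is expected in this assay although a larger rise stays possible. The expected step is a 1.4-fold higher number from compound 3 to compound 4 (0.14 log units; within the scatter) as estimated here. Compound 4 is estimated at 1500 nM with an expected range of 300 nM to 8000 nM for now.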

Compound 4, maximal plasma concentration: 130 nM
The estimate for compound 4 lay 12-fold (1.06 log units) above the measured number, and the stated range ends above it.
By their numbers in this assay, from the lowest: compound 4; then compounds 3 and 1 (each within the scatter of the next); then compound 2.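

In this assay this aromatic carbon can carry a sharp loss as well as a gain: 4-hydroxyphenyl gives an 8.3-fold lower number from compound 3 to compound 4 (0.92 log units; beyond the scatter) against trifluoromethyl, a 14-fold lower number from compound 1 to compound 4 (1.15 log units; beyond the scatter) against 2,3-difluorophenyl and a 200-fold lower number from compound 2 to compound 4 (2.29 log units; beyond the scatter) against 2-fluoropyridin-3-yl. A six-membered aromatic ring of carbon only thus does not by itself keep the number near that of compound 1, and compound 4 stands lowest of the four. Nothing at hand explains this drop. Open, as far as these compounds go, is whether the hydroxyl or the ring carries the loss: 4-methoxyphenyl or 4-aminophenyl at this carbon would separate the two.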